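From a Methylpyrazole to a Methylpyridine on a Shared Core

This account rests on a few compounds, and the source may have more. Where it says the series, first, only, none or still open, it means among the compounds named here.

Of the compounds shown here, three have so far been measured in a physicochemical assay for solubility, read by LC-MS, in phosphate buffer, with a stated time of 24 h, at pH 7.4; a higher number here means a more soluble compound, a lower number a less soluble compound. Compound 1 `Cn1cc(-c2cnc(NCc3c(F)ccc4c3CCO4)c3cn[nH]c(=O)c23)cn1` gives 1000 nM in this assay, the lowest of the three numbers. Compound 2 `C[C@@H]1CC(=O)N(c2cnc(NCc3c(F)ccc4c3CCO4)n3cnnc23)C1` gives 130000 nM in this assay, and compound 3 `CN(C)Cc1ccc(C(=O)Nc2cnc(NCc3c(F)ccc4c3CCO4)n3cnnc23)cc1` gives 520000 nM. Among the compounds with values here, both of these sit far above compound 1, and both gaps lie beyond the scatter; compounds 2 and 3 are built on a different core, so no single-point step connects either of them to compound 1.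

Compound 4 `Cc1ncccc1-c1cnc(NCc2c(F)ccc3c2CCO3)c2cn[nH]c(=O)c12` keeps the core of compound 1 and changes one group: 2-methylpyridin-3-yl in place of 1-methyl-1H-pyrazol-4-yl on an aromatic carbon. The leaving group and the entering group are both uncharged aromatic rings attached at the same place, with the 2-methylpyridin-3-yl replacing the 1-methyl-1H-pyrazol-4-yl.

Within the data shown here, no pair among the measured compounds shares this exact change, so nothing among them sizes it. The expectation is a step from compound 1 to compound 4 of a 1.5-fold higher number from compound 1 to compound 4 (0.18 log units; within the scatter), modest and quite possibly within the scatter. Compound 4 is accordingly expected to give about 1500 nM in this assay, within a range from 400 nM to 6000 nM.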

Compound 4, solubility: < 2000 nM
Compound 4 was reported as a limit (the forecaster's own chance of this, stated with the estimate: 5%); the middle value lies beyond the limit too.
By their numbers in this assay, from the lowest: compound 1; then compound 2; then compound 3.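

In this assay compound 4 gives < 2000 nM, which is a limit and not a number. The step between compound 1 and compound 4 therefore cannot be read. The compounds shown leave open whether 2-methylpyridin-3-yl in place of 1-methyl-1H-pyrazol-4-yl on the shared core changes the number in this assay, and in which direction.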